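A few compounds are considered here, and "the series" means these few. Any claim that something is new, unique, unknown or untested is made for them only; others in the source may bear on it.

In a functional assay on SK-OV-3 cells (Homo sapiens) for cytotoxicity (a higher number here means a weaker inhibitor of growth, a lower number a stronger inhibitor of growth), compound 1 (`CSc1ccc(C2=C(c3ccc(F)c(F)c3)C(=O)N3CCCC3C2)cc1`) gives 100 nM and compound 2 (`CSc1ccc(C2=C(c3ccc(Br)cc3)C(=O)N3CCCC3C2)cc1`) gives 9000 nM. Among the measured compounds shown here, compound 2 therefore holds the higher of the two numbers so far and is the weaker inhibitor of growth.

Next in line is compound 3 (`CSc1ccc(C2=C(c3ccc(F)cc3)C(=O)N3CCCC3C2)cc1`). The change is fluoro in place of bromo on an aromatic carbon, in words fluoro in place of bromo on an aromatic carbon, para to a large group.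

For the measured compounds named here, only one measured step bears on it: a 90-fold higher number from compound 1 to compound 2 (1.95 log units; beyond the scatter), large and beyond the scatter, with 4-bromophenyl in place of 3,4-difluorophenyl. Compound 3 leaves the 4-bromophenyl of compound 2 behind and carries a 4-fluorophenyl, a group not yet measured. Going by the values given here, no compound in hand shows how much of that step belongs to the bromo alone, so only part of it is expected to be recovered, though still a step beyond the scatter.

The expected change, toward a lower number in this assay, is a 23-fold lower number from compound 2 to compound 3 (1.35 log units; beyond the scatter). For compound 3 the estimated value is 400 nM, with an expected range of 90 nM to 2500 nM.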

Compound 3, concentration for 50% growth inhibition: 30000 nM
Compound 3: middle estimate off by 75-fold (1.88 log units), on the low side; measured number above the stated range.
By their numbers in this assay, from the lowest: compound 1; then compound 2; then compound 3.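

In this assay, fluoro in place of bromo on an aromatic carbon, para to a large group, gives a 3.3-fold higher number from compound 2 to compound 3 (0.52 log units; beyond the scatter), so on this ring the 4-bromophenyl of compound 2 stands at the lower number of the two single-halogen groups, and exchanging the halogen at this carbon does not recover the low number of compound 1. The main effect at this ring appears in the other new step: going from 3,4-difluorophenyl to 4-fluorophenyl, hydrogen in place of fluoro gives a 300-fold higher number from compound 1 to compound 3 (2.48 log units; beyond the scatter), a change of one atom that exceeds the whole step from compound 1 to the bromo compound. Nothing at hand explains why this one fluoro matters so much or why bromo and fluoro differ in this order.

Among the compounds shown here, still open is whether the low number of compound 1 needs both fluoro atoms together or only the one lost in compound 3, which a phenyl ring with no substituent would help to place as a baseline. A 3,4-dichlorophenyl or a 4-chlorophenyl would show whether other halogens follow the same order on the shared core.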